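The source may hold more compounds than are shown below. What is called first, only, known or untested is meant among the compounds shown, and "the series" means these compounds.

Compound 1 `COc1ccc(/C=C/C(=O)/C=C(O)/C=C/c2ccc(OC(C)(C)C(=O)Nc3ccc([N+](=O)[O-])c(C(F)(F)F)c3)c(OC)c2)cc1OC` and compound 2 `COc1ccc(/C=C/C(=O)/C=C(O)/C=C/c2ccc(OC(C)(C)C(=O)Nc3ccc(C#N)c(C(F)(F)F)c3)c(OC)c2)cc1OC` share one core and differ by a single change, (cyano in place of nitro on an aromatic carbon). In a functional assay on PC-3 cells (Homo sapiens) for cytotoxicity, read by sulforhodamine B assay, with a stated time of 72 h (a higher number here means a weaker inhibitor, a lower number a stronger inhibitor), compound 1 gives only a limit, > 100000 nM. In this assay compound 2 likewise gives only a limit, > 100000 nM. The step that the two limits leave unreadable from compound 1 to compound 2 therefore cannot be read, since the limit of > 100000 nM in this assay, at which 2 of the 3 values shown sit, holds both ends of it. Compound 3 `COc1ccc(/C=C/C(=O)/C=C(O)/C=C/c2ccc(OCC(C)(O)C(=O)Nc3ccc([N+](=O)[O-])c(C(F)(F)F)c3)c(OC)c2)cc1OC` carries a different core; the difference between the two cores is not broken down here. In this assay, among the compounds with values here, compound 3 gives 39100 nM, the only plain number among the three measured compounds. Compound 4 `COc1ccc(/C=C/C(=O)/C=C(O)/C=C/c2ccc(OCC(C)(O)C(=O)Nc3ccc(C#N)c(C(F)(F)F)c3)c(OC)c2)cc1OC` is compound 3 with the same change, (cyano in place of nitro on an aromatic carbon). The earlier instance of this change gives no readable size, so the expectation for compound 4 rests on compound 3, which gives 39100 nM in this assay. The step of a 1.3-fold higher number from compound 3 to compound 4 (0.11 log units; within the scatter) is expected to be small, within the usual scatter. Compound 4 is estimated at 50000 nM, with a likely range from 20000 nM to 150000 nM.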

Compound 4, half-maximal inhibitory concentration: 100000 nM
For compound 4 the middle estimate is 2.0-fold (0.30 log units) below the measured one; the measured number falls inside the stated range.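

In this assay, cyano in place of nitro on the aromatic carbon gives a 2.6-fold higher number from compound 3 to compound 4 (0.41 log units; beyond the scatter), a modest change toward a weaker inhibitor on the core of compound 3. The same change on the core of compound 1 cannot be read, because compound 1 and compound 2 both stand at a limit of the assay: the limit of > 100000 nM in this assay, at which 2 of the 4 values shown sit. So the series offers one readable instance of this change, which does not show whether its size carries from one core to another.

The compounds shown leave open how an amine or a carboxylic acid in place of nitro or cyano on that aromatic carbon would read in this assay. Also open, as far as these compounds go, is how a longer chain in the linker of the core of compound 3 would read.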